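The source may hold more compounds than are shown below. What is called first, only, known or untested is meant among the compounds shown, and "the series" means these compounds.

In an ADME assay on HEK293 cells (Homo sapiens) for cytotoxicity, with a stated time of 72 h (a higher number here means that more compound is needed for the effect, a lower number that less compound is needed), two compounds have been measured so far. Within the data shown here, compound 2 (`COc1ccc(/C=C/[C@@](C)(/C=C/c2ccc(O)c(C=O)c2)CCC=C(C)C)cc1`) gives 2270 nM, the only true number available. Compound 1 (`C=C[C@@](C)(/C=C/c1ccc(O)c(/C=C/C#N)c1)CCC=C(C)C`) gives > 36600 nM, which is a limit and not a number.

Compound 3 (`COc1ccc(/C=C/[C@@](C)(/C=C/c2ccc(O)c(/C=C/C#N)c2)CCC=C(C)C)cc1`) departs from compound 2 in one place: 2-cyanoethenyl in place of formyl on an aromatic carbon. In words, 2-cyanoethenyl stands in place of formyl on an aromatic carbon, ortho to a hydroxy group. Among the measured compounds shown here, no measured pair isolates this change, so the expectation rests on thin ground. The 2-cyanoethenyl group also occurs in compound 1, whose reading of > 36600 nM is a limit. A shift towards more compound being needed is therefore expected, not one towards less. The expected move is moderate, a 2.6-fold higher number from compound 2 to compound 3 (0.42 log units; beyond the scatter), and beyond the usual scatter. For compound 3 the estimated value is 6000 nM, with an expected range from 1800 nM to 25000 nM.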

Compound 3, half-maximal effective concentration: > 36600 nM
Compound 3: no number, only a limit; the forecaster's own chance of this, stated with the estimate: 15%; at least 6.1-fold (0.78 log units) between middle value and limit.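

In this assay, the aromatic carbon ortho to a hydroxy group now has its first measured step, with 2-cyanoethenyl in place of formyl giving an at least 16-fold higher number from compound 2 to compound 3 (1.20 log units; beyond the scatter). Compound 1 and compound 3, the two compounds carrying 2-cyanoethenyl, both stand at a limit and give no number: the limit of > 36600 nM in this assay, at which 2 of the 3 values shown sit. The step from compound 1 to compound 3, 2-(4-methoxyphenyl)ethenyl in place of vinyl, cannot be read, as both values are limits.

The compounds shown leave open whether formyl on the vinyl compound would give a true number, and so what the exchange of vinyl does on its own. They also leave open how an amine, a carboxylic acid or a longer chain in place of formyl on this aromatic carbon would read.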